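Swapping the thiadiazolylsulfanyl arm of compound 3 for a pyrimidinyloxy arm

The source may hold more compounds than are shown below. What is called first, only, known or untested is meant among the compounds shown, and "the series" means these compounds.

Compound 1 `CC(C)[C@H](NC(=O)COc1cccc2ccccc12)C(=O)N[C@@H](CC(=O)O)C(=O)CSc1nc(-c2ccccc2)c(-c2ccccc2)[nH]1`: > 200000 nM
Compound 2 `CC(C)[C@H](NC(=O)COc1cccc2ccccc12)C(=O)N[C@@H](CC(=O)O)C(=O)CSc1nncn1C`: > 200000 nM
Compound 3 `Cc1nnc(SCC(=O)[C@H](CC(=O)O)NC(=O)[C@@H](NC(=O)COc2cccc3ccccc23)C(C)C)s1`: 190000 nM

In a functional assay on Jurkat cells (Homo sapiens) for inhibition (a lower number here means a stronger inhibitor, a higher number a weaker inhibitor), compound 1 gives only a limit of the assay, > 200000 nM. Compound 2 likewise gives only a limit, > 200000 nM. Among the compounds with values here, compound 3 is the one compound with a number, 190000 nM, and it sits close to the limit of > 200000 nM in this assay, at which 2 of the 3 values shown sit. Within the data shown here, the one step that can be traced, an at least 1.0-fold lower number from compound 2 to compound 3 (0.02 log units; that floor lies within the scatter), lies within the scatter.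

Compound 4 `CC(C)[C@H](NC(=O)COc1cccc2ccccc12)C(=O)N[C@@H](CC(=O)O)C(=O)COc1cc(C(F)(F)F)ncn1` differs from compound 3 as follows: (6-(trifluoromethyl)pyrimidin-4-yl)oxy in place of (5-methyl-1,3,4-thiadiazol-2-yl)sulfanyl on a saturated chain carbon bound to a carbonyl carbon. Among the measured compounds shown here, no measured step covers this change, and the only step available concerned a different swap on the sulfur. Compound 4 is therefore expected to show no step beyond the scatter, no change at the digits printed from compound 3 to compound 4 (within the scatter), and its estimate in this assay is 190000 nM, in the range 60000 nM to 450000 nM.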

Compound 4, half-maximal inhibitory concentration: > 200000 nM
Compound 4 ended at the assay's limit; the forecaster's own chance of this, stated with the estimate: 55%; at least 1.0-fold (0.02 log units) between middle value and limit.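

In this assay, replacing the sulfur-linked thiadiazole arm with the (6-(trifluoromethyl)pyrimidin-4-yl)oxy arm gives an at least 1.0-fold higher number from compound 3 to compound 4 (0.02 log units; that floor lies within the scatter), so this larger, oxygen-linked six-membered ring shows no gain at this position. The step from compound 2 to compound 4 cannot be read, as both ends are limits. A change of both ring and linking atom thus leaves the series where it was, with one more compound at the limit: the limit of > 200000 nM in this assay, at which 3 of the 4 values shown sit.

Still open, going by these compounds, is whether any arm at this position can bring a value clear of that limit. An amine on the ring, or a longer chain in place of the arm, remains untested among the compounds shown.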